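Swapping methoxy for nitro in compound 2

The source may hold more compounds than are shown below. What is called first, only, known or untested is meant among the compounds shown, and "the series" means these compounds.

Among the compounds with values here, in a functional assay on HL-60 cells (Homo sapiens) for inhibition, read by CCK-8 assay, with a stated time of 48 h, tested at 20 uM (a lower number here means less inhibition of growth, a higher number more inhibition of growth at the concentration tested), compound 2 (`COc1ccc(S(=O)(=O)Oc2ccccc2/C=C(\C#N)C(=O)Nc2nnc(Cc3ccc(Cl)cc3)s2)cc1`) gives 99%, the higher of the two numbers measured so far. Compound 1 (`N#C/C(=C\c1ccccc1OS(=O)(=O)c1ccc([N+](=O)[O-])cc1)C(=O)Nc1nnc(Cc2cccc3ccccc23)s1`) gives 18%, which lies far lower and beyond the scatter. These two compounds differ in more than one place, so their gap cannot be assigned to any single structural change.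

The next compound is compound 3 (`N#C/C(=C\c1ccccc1OS(=O)(=O)c1ccc([N+](=O)[O-])cc1)C(=O)Nc1nnc(Cc2ccc(Cl)cc2)s1`), which follows from compound 2 by one change: nitro in place of methoxy on an aromatic carbon. Put in terms of the whole group, 4-methoxyphenyl becomes 4-nitrophenyl. Within the data shown here, no measured pair shows this change alone. Among the measured compounds shown here, the only hint is that compound 1, which also carries the 4-nitrophenyl group, gives 18%. The rest of compound 3 is that of compound 2, which gives 99%, so a moderate fall in this assay is expected, probably beyond the scatter, rather than a collapse. The expected step of a number 24 percentage points lower from compound 2 to compound 3 (beyond the scatter) is therefore downward, though its size is uncertain. For compound 3 the estimated value is 75%, with an expected range from 35% to 100%.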

Compound 3, percent growth inhibition at one concentration: 34%
Compound 3: the middle estimate sits 41 percentage points above what was measured, outside the stated range (below it).
By their numbers in this assay, from the lowest: compound 1; then compound 3; then compound 2.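

Within the data shown here, this pair gives the first clean reading of the substituent on the aromatic carbon para to a large group. In this assay, nitro in place of methoxy at this position gives a number 65 percentage points lower from compound 2 to compound 3 (beyond the scatter), so the outcome here depends strongly on which of these two groups is present, even with the rest of the molecule unchanged. With the 4-nitrophenyl group held constant, 4-chlorophenyl in place of naphthalen-1-yl on the saturated chain carbon gives a number 16 percentage points higher from compound 1 to compound 3 (beyond the scatter), a modest step that does not restore the high number of compound 2.

Nothing available explains why the exchange of methoxy for nitro has so large an effect.

The compounds shown leave open whether an amine, a carboxylic acid or a simple methyl group at this position would fall nearer to compound 2 or to compound 3. They also leave open whether the step from 4-methoxyphenyl to 4-nitrophenyl would have a similar size with naphthalen-1-yl in place of 4-chlorophenyl, since each of these changes is seen only once.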